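The source may report more compounds than this note shows. Statements on the series, on what has been measured and on what is new or still open speak of the compounds shown alone.

In an ADME assay on PA-1 cells (Homo sapiens) for cytotoxicity, read by MTT assay, with a stated time of 72 h (on this read-out lower numbers stand for stronger inhibition and higher numbers for weaker inhibition), compound 1 `COc1ccc(C2=C(c3cc(OC)c(OC)c(OC)c3)C(=O)C(O[SiH2]C(C)(C)C)C2)cc1` gives 7 ug/mL and compound 2 `COc1ccc(C2=C(c3cc(OC)c(OC)c(OC)c3)C(=O)C(O[SiH2]C(C)(C)C)C2)cc1OC(C)C` gives 7.1 ug/mL so compound 2 stands level with compound 1 within the scatter, and no other number is available yet. Next comes compound 3 `COc1cc(C2=C(c3ccc(SC)cc3)CC(O[SiH2]C(C)(C)C)C2=O)cc(OC)c1OC` which has no measurement so far. The change from compound 2 is 4-(methylsulfanyl)phenyl in place of 3-isopropoxy-4-methoxyphenyl on a double-bonded ring carbon in which 4-(methylsulfanyl)phenyl takes the place of 3-isopropoxy-4-methoxyphenyl on a double-bonded ring carbon next to the ring atom that bears a 3,4,5-trimethoxyphenyl group. Within the data shown here, one measured step bears on this: a 1.0-fold higher number from compound 1 to compound 2 (0.01 log units; within the scatter) for isopropoxy in place of hydrogen on an aromatic carbon of the group that now leaves. That step covers only part of the change. Among the measured compounds shown here, no measured step brings in 4-(methylsulfanyl)phenyl, so the basis for any forecast is thin. The expected size of this change is a 1.1-fold lower number from compound 2 to compound 3 (0.04 log units; within the scatter) and no shift beyond the scatter is expected in this assay in either direction. Compound 3 is estimated at 6.5 ug/mL with a range from 2.5 ug/mL to 16 ug/mL on this read-out.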

Compound 3, half-maximal inhibitory concentration: < 1 ug/mL
Compound 3 was reported as a limit (the forecaster's own chance of this, stated with the estimate: 5%); at least 6.5-fold (0.81 log units) between middle value and limit.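

In this assay, the aryl group on the double-bonded ring carbon is now shown to matter: earlier, adding isopropoxy to this group gave only a 1.0-fold higher number from compound 1 to compound 2 (0.01 log units; within the scatter), whereas 4-(methylsulfanyl)phenyl in place of 3-isopropoxy-4-methoxyphenyl gives an at least 7.1-fold lower number from compound 2 to compound 3 (0.85 log units; beyond the scatter). Among these compounds, the cleaner comparison is the single exchange of methylsulfanyl for methoxy on an aromatic carbon, which gives an at least 7.0-fold lower number from compound 1 to compound 3 (0.84 log units; beyond the scatter), so this one change is enough to move the number beyond the scatter without any isopropoxy group being involved. The value of compound 3, < 1 ug/mL, is a limit and not a number, so both steps give only a minimum size: the limit of < 1 ug/mL in this assay, at which 1 of the 3 values shown sits.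

How far compound 3 lies past that limit stays open, and methylsulfanyl is the only sulfur-bearing group among the compounds shown, so a single pair cannot tell whether ethylsulfanyl or methylsulfonyl on the same aromatic carbon would give a comparable step. Also open is whether the step depends on the shared silyl ether, since every compound shown carries it and none has a free hydroxyl group on that ring carbon.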